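The source may hold more compounds than are shown below. What is called first, only, known or untested is meant among the compounds shown, and "the series" means these compounds.

Measured in a functional assay on PC-3M cells (Homo sapiens) for cytotoxicity, read by MTT assay, with a stated time of 48 h; a lower number here means a stronger inhibitor, a higher number a weaker inhibitor:
- compound 1 `Cc1nnc(SCC(=O)c2ccc(Cl)cc2)n1N1C(=O)c2ccccc2C1=O`: > 200000 nM, a limit of the assay, not a number
- compound 2 `Cc1ccc(C(=O)CSc2nnc(C)n2N2C(=O)c3ccccc3C2=O)cc1`: > 200000 nM, a limit of the assay
- compound 3 `CCCc1nnc(SCC(=O)c2ccc(Cl)cc2)n1N1C(=O)c2ccccc2C1=O`: > 200000 nM, a limit of the assay

Compound 2 differs from compound 1 by methyl in place of chloro on an aromatic carbon. The step that the two limits leave unreadable from compound 1 to compound 2 has no readable size because both values sit at the limit of > 200000 nM in this assay, at which 3 of the 3 values shown sit. Compound 3 differs from compound 1 by ethyl in place of hydrogen on a saturated chain carbon bound to an aromatic carbon, and this is also how the core of compound 3 differs from the core of compound 1. The step that the two limits leave unreadable from compound 1 to compound 3 is likewise unreadable because both values sit at the limit of > 200000 nM in this assay, at which 3 of the 3 values shown sit.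

Compound 4 `CCCc1nnc(SCC(=O)c2ccc(C)cc2)n1N1C(=O)c2ccccc2C1=O` is not yet measured. It differs from compound 3 by methyl in place of chloro on an aromatic carbon, the same change as from compound 1 to compound 2, at the same place word for word, made here on the core of compound 3. The change occurs twice among these compounds, and in the only measured pair it gave no readable step.

In this assay the step from compound 3 to compound 4 is expected to be a step that the limit leaves unreadable from compound 3 to compound 4, set beside the earlier step that the two limits leave unreadable from compound 1 to compound 2; this rests on every measured value sitting at the limit of > 200000 nM in this assay, at which 3 of the 3 values shown sit, and on nothing within the series pointing away from it. Compound 4 is therefore estimated at 300000 nM, between 100000 nM and 1000000 nM, and is expected most likely to be reported as a limit rather than a number.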

Compound 4, half-maximal inhibitory concentration: > 200000 nM
Compound 4 was reported as a limit; the forecaster's own chance of this, stated with the estimate: 85%; the middle value does not contradict the limit.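

In this assay compound 4 gives > 200000 nM as a limit of the assay, not a number. No new step can be read from compound 2 or compound 3 to compound 4, because all four compounds sit at the same limit: the limit of > 200000 nM in this assay, at which 4 of the 4 values shown sit. The compounds shown leave open whether either change, chloro to methyl or the longer chain, alters potency, and in which direction.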